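Para-Methyl on the Anilide: Compound 2 to Compound 3

This account rests on a few compounds, and the source may have more. Where it says the series, first, only, none or still open, it means among the compounds named here.

Measured compounds:
compound 1 `Nc1nc(CC2CCCC2)c(-c2ccccc2Br)n1CC(=O)Nc1ccccc1`, 24300 nM
compound 2 `COc1ccc(Cc2nc(N)n(CC(=O)Nc3ccccc3)c2-c2ccccc2Br)cc1`, 1400 nM

In a functional assay on A-375 cells (Homo sapiens) for antiproliferative activity, read by MTT assay, with a stated time of 48 h (a lower number here means a stronger inhibitor, a higher number a weaker inhibitor), compound 2 gives 1400 nM, the lowest of the two numbers; the nearest is compound 1 at 24300 nM. Within the data shown here, the only measured step, a 17-fold lower number from compound 1 to compound 2 (1.24 log units; beyond the scatter), changes the group on the saturated chain carbon and says nothing about the anilide ring. Compound 3 `COc1ccc(Cc2nc(N)n(CC(=O)Nc3ccc(C)cc3)c2-c2ccccc2Br)cc1` carries the change (methyl in place of hydrogen on an aromatic carbon). Among the measured compounds shown here, with no step bearing on this position, the number for compound 3 is expected to stay within the scatter, so a 1.2-fold lower number from compound 2 to compound 3 (0.07 log units; within the scatter) is the estimated step. Compound 3 is estimated at 1200 nM, between 400 nM and 3500 nM.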

Compound 3, half-maximal inhibitory concentration: 2400 nM
The estimate for compound 3 lay 2.0-fold (0.30 log units) below the measured number; low and high end bracket the measured number.
By their numbers in this assay, from the lowest: compounds 2 and 3 (each within the scatter of the next); then compound 1.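

In this assay, among these compounds, the anilide ring is tested for the first time: methyl in place of hydrogen, para to a large group, gives a 1.7-fold higher number from compound 2 to compound 3 (0.23 log units; within the scatter) and so cannot be told apart from no change. This differs from the group on the saturated chain carbon, where a 17-fold lower number from compound 1 to compound 2 (1.24 log units; beyond the scatter) is a large step. Nothing measured here offers a reason for this result. On these data alone, whether this tolerance extends beyond a single methyl stays open. A carboxylic acid, an amine or a longer chain at this position could still move the number in either direction.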